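The source may hold more compounds than are shown below. What is called first, only, known or untested is meant among the compounds shown, and "the series" means these compounds.

Measured in an ADME assay on HEK-293T cells (Homo sapiens) for inhibition, read by CCK-8 assay, with a stated time of 48 h, tested at 20 uM; a lower number here means less inhibition of growth, a higher number more inhibition of growth at the concentration tested:
- compound 1 `COc1ccc(Cc2nnc(NC(=O)/C(C#N)=C/c3ccccc3OS(=O)(=O)c3ccc(OC)cc3)s2)cc1` gives 30%
- compound 2 `COc1ccc(S(=O)(=O)Oc2ccccc2/C=C(\C#N)C(=O)Nc2nnc(Cc3ccccc3)s2)cc1` gives 23%
- compound 3 `Cc1ccc(S(=O)(=O)Oc2ccccc2/C=C(\C#N)C(=O)Nc2nnc(Cc3ccc(Cl)cc3)s2)cc1` gives 20%

All three values lie within the usual scatter of one another, so compound 3 cannot be told apart from compound 1 or compound 2 in this assay.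

Compound 4 `COc1ccc(S(=O)(=O)Oc2ccccc2/C=C(\C#N)C(=O)Nc2nnc(Cc3ccc(Cl)cc3)s2)cc1` differs from compound 3 by one small change: methoxy in place of methyl on an aromatic carbon that is, methoxy in place of methyl on an aromatic carbon, para to a large group.

Among the compounds with values here, no measured step makes exactly this change. The closest is a number 7 percentage points lower from compound 1 to compound 2 (within the scatter) which swaps a methoxy for hydrogen elsewhere in the molecule and stays within the scatter. Compound 2 also carries the (4-methoxyphenyl)sulfonyl group of compound 4, and compound 2 gives 23% in the same narrow band as the others.

The expected a number 3 percentage points higher from compound 3 to compound 4 (within the scatter) is therefore no step beyond the scatter, with no clear direction. For compound 4 the estimated value is 23% with an expected range from 11% to 35% in this measurement.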

Compound 4, percent growth inhibition at one concentration: 26%
Beside the measured number, compound 4's estimate is 3 percentage points below it, within the range that was stated.
By their numbers in this assay, from the lowest: compounds 3, 2, 4 and 1 (each within the scatter of the next).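

Read directly, methoxy in place of methyl on the aromatic carbon para to a large group gives a number 6 percentage points higher from compound 3 to compound 4 (within the scatter) in this assay, so the (4-methylphenyl)sulfonyl and (4-methoxyphenyl)sulfonyl groups cannot be told apart in this measurement. With the (4-methoxyphenyl)sulfonyl group kept, chloro in place of hydrogen gives a number 3 percentage points higher from compound 2 to compound 4 (within the scatter) and chloro in place of methoxy gives a number 4 percentage points lower from compound 1 to compound 4 (within the scatter) at the other aromatic ring, so these groups cannot be told apart there either. No supporting evidence is available to explain these small steps.

Going by these compounds, whether an amine, a carboxylic acid or a longer chain at the same aromatic carbon would give a step beyond the scatter stays open. So does whether these compounds would still match one another at a different concentration.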